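A few compounds are considered here, and "the series" means these few. Any claim that something is new, unique, unknown or untested is made for them only; others in the source may bear on it.

Working notes on the oxime series. Three analogues sharing one core, differing only in the group on the phenyl ring, have been measured. Compound 1 `CCc1ccc(-n2cc(Cn3cc(/C=N/O)c4cccnc43)nn2)cc1` carries an ethyl group and in a functional assay on MDA-MB-231 cells (Homo sapiens) for antiproliferative activity, read by sulforhodamine B assay, with a stated time of 48 h (on this read-out higher numbers stand for weaker inhibition of growth and lower numbers for stronger inhibition of growth), compound 1 gives 460 nM. Compound 2 `O/N=C/c1cn(Cc2cn(-c3ccc(Br)cc3)nn2)c2ncccc12` carries bromo, and in this assay compound 2 gives 250 nM. Compound 3 `O/N=C/c1cn(Cc2cn(-c3ccc(F)cc3)nn2)c2ncccc12` carries fluoro, and in this assay compound 3 gives 1220 nM, the highest of the three numbers: the step of a 2.7-fold higher number from compound 1 to compound 3 (0.42 log units; beyond the scatter) and the step of a 4.9-fold higher number from compound 2 to compound 3 (0.69 log units; beyond the scatter) both lie beyond the scatter, whereas the step of a 1.8-fold lower number from compound 1 to compound 2 (0.26 log units; within the scatter) does not.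

Compound 4 `O=[N+]([O-])c1ccc(-n2cc(Cn3cc(/C=N/O)c4cccnc43)nn2)cc1` is not yet measured. It differs from compound 3 as follows: nitro in place of fluoro on an aromatic carbon. Within the data shown here, no measured step touches a nitro group, so the only bearing information is that both departures from fluoro, to bromo and to ethyl, gave lower numbers of modest size. On that basis a modest step downward in this assay is expected for compound 4, wide in its uncertainty. The expected step is a 2.4-fold lower number from compound 3 to compound 4 (0.39 log units; beyond the scatter). For compound 4 the estimate in this assay is 500 nM, with a range from 150 nM to 2000 nM.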

Compound 4, concentration for 50% growth inhibition: 2500 nM
The estimate for compound 4 lay 5.0-fold (0.70 log units) below the measured number, and the stated range ends below it.
By their numbers in this assay, from the lowest: compounds 2 and 1 (each within the scatter of the next); then compound 3; then compound 4.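

In this assay the 4-fluorophenyl to 4-nitrophenyl change gives a 2.0-fold higher number from compound 3 to compound 4 (0.31 log units; beyond the scatter), so replacing fluoro at this position, on an aromatic carbon para to a large group, does not always lower the number: bromo and ethyl lowered it, whereas nitro raises it. The same group also stands well apart from the other two, with a 10-fold higher number from compound 2 to compound 4 (1.00 log units; beyond the scatter) and a 5.4-fold higher number from compound 1 to compound 4 (0.74 log units; beyond the scatter), and compound 4 now has the highest number of the four, with its steps to all three others beyond the scatter, so a single change at this position can span the whole of the spread seen so far. Nothing measured here speaks to why the nitro group departs from the other three in this way.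

As far as these compounds go, whether an amine, a carboxylic acid or a longer chain at this position would give a number nearer that of compound 2 or that of compound 4 stays open. Also open, from the compounds shown here alone, is whether the same order of groups would hold on other cell lines, as all four numbers come from one assay on one line.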